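The source may hold more compounds than are shown below. What is called first, only, known or untested is meant among the compounds shown, and "the series" means these compounds.

Series notes. All three measured compounds carry the same chain ending in the triazole; they differ in the aryl group and in a hydrocarbon arm on the chain. Compound 1 `CCC[C@H](CCn1cncn1)c1ccc(C)cc1` gives 47.2 ug/mL in an ADME assay on RD cells (Homo sapiens) for cytotoxicity, read by MTT assay, with a stated time of 3 days; on this read-out lower numbers stand for higher toxicity in this test and higher numbers for lower toxicity in this test. Compound 2 `c1ccc(C[C@H](CCn2cncn2)c2ccccc2)cc1` gives 55.4 ug/mL in this assay, and compound 3 `c1ccc(C[C@@H](CCn2cncn2)c2ccccc2)cc1` gives 56 ug/mL. For the measured compounds named here, the only one-place step among them is a 1.0-fold higher number from compound 2 to compound 3 (0.00 log units; within the scatter); the pair is the same set of atoms drawn in opposite configuration, so the fact that compounds 2 and 3 differ only in the configuration as drawn carries no information on a substituent change. Compound 3 has the largest number of the three, but its gaps to compound 2 and compound 1 are both within the scatter, so the three compounds cannot be ordered on this read-out.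

Compound 4 `COc1ccc([C@H](CCn2cncn2)Cc2ccccc2)cc1` is not yet measured. Against compound 3 the change is methoxy in place of hydrogen on an aromatic carbon, on the aryl ring that carries the chain, para to a large group. Going by the values given here, no measured step adds or removes a ring substituent, so there is no direct precedent for it; the one measured step was flat. Under these conditions the expectation for the step of a 1.1-fold lower number from compound 3 to compound 4 (0.03 log units; within the scatter) is no change beyond the scatter, with a wide uncertainty. The number for compound 4 is therefore estimated at 52 ug/mL, expected to fall between 25 ug/mL and 110 ug/mL in this assay.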

Compound 4, half-maximal cytotoxic concentration: 66 ug/mL
Compound 4: the middle estimate sits 1.3-fold (0.10 log units) below what was measured; the measured number falls inside the stated range.
By their numbers in this assay, from the lowest: compounds 1, 2, 3 and 4 (each within the scatter of the next).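

The first ring substituent in the series, methoxy in place of hydrogen on an aromatic carbon para to a large group, gives a 1.2-fold higher number from compound 3 to compound 4 (0.07 log units; within the scatter) in this assay. This position therefore accepts methoxy, an added group of 2 heavy atoms with 1 hydrogen-bond acceptor, without a change beyond the scatter on this read-out, so the flat picture in the series now covers one substituent change as well as the configuration pair. For the compounds shown here, nothing given here accounts for the size of this step, and the only other information on the series concerns configuration, not a ring substituent.

This is a single group at a single position, so the compounds shown leave open whether an amine or a carboxylic acid on the same aromatic carbon would also stay within the scatter. Also open, from the compounds shown here alone, is whether methoxy would read the same on the second aromatic ring of compound 4, or in the opposite configuration at the chain carbon.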